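This account rests on a few compounds, and the source may have more. Where it says the series, first, only, none or still open, it means among the compounds named here.

Compound 1, `CCC(Sc1nc2c(cnn2C)c(=O)n1-c1ccccc1)c1ccccc1`, gives 119 nM in an assay on isolated protein for inhibition of Retinaldehyde dehydrogenase 3 (Homo sapiens); on this read-out lower numbers stand for stronger inhibition and higher numbers for weaker inhibition.
Compound 2, `COc1cccc(C(C)Sc2nc3c(cnn3C)c(=O)n2-c2ccccc2)c1`, gives 174 nM in this assay.
Compound 3, `CC(Sc1nc2c(cnn2C)c(=O)n1-c1ccccc1)c1cccnc1`, gives 95 nM in this assay.

Among these three, compound 3 gives the lowest number, but its gaps to both neighbours are small: a 1.3-fold lower number from compound 1 to compound 3 (0.10 log units; within the scatter) and a 1.8-fold lower number from compound 2 to compound 3 (0.26 log units; within the scatter), each within the scatter of the measurement. The three compounds share one core and differ only in the group attached to the saturated chain carbon bound to a saturated chain carbon and a sulfur.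

Compound 4, `CC(Sc1nc2c(cnn2C)c(=O)n1-c1ccccc1)c1cncnc1`, continues this series with a change at the same place: pyrimidin-5-yl in place of pyridin-3-yl on a saturated chain carbon bound to a saturated chain carbon and a sulfur. The step from compound 2 to compound 3 is the one that bears on it most directly, as it also exchanged one six-membered ring for another on that carbon, and it stayed within the scatter. The step from compound 1 to compound 3 was likewise within the scatter. Among the measured compounds shown here, nothing measured so far suggests that a second ring nitrogen at this position would move this assay far in either direction, so compound 4 is expected to fall close to compound 3, with the estimated step of a 1.2-fold higher number from compound 3 to compound 4 (0.08 log units; within the scatter) not exceeding the scatter. Compound 4 is therefore estimated at 115 nM, within a range from 50 nM to 270 nM.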

Compound 4, half-maximal inhibitory concentration: 100 nM
Compound 4: the middle estimate sits 1.2-fold (0.06 log units) above what was measured, within the range that was stated.
By their numbers in this assay, from the lowest: compounds 3, 4, 1 and 2 (each within the scatter of the next).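

Setting pyrimidin-5-yl in place of pyridin-3-yl on the saturated chain carbon bound to a saturated chain carbon and a sulfur leaves the reading in this assay unresolved, with a 1.1-fold higher number from compound 3 to compound 4 (0.02 log units; within the scatter). The pyrimidin-5-yl group also cannot be separated from the groups without a ring nitrogen, with a 1.7-fold lower number from compound 2 to compound 4 (0.24 log units; within the scatter) and a 1.2-fold lower number from compound 1 to compound 4 (0.08 log units; within the scatter), so rings carrying no, one or two ring nitrogens at this place all give readings that the scatter does not distinguish. Nothing available explains this flat response.

On these data alone, all four compounds carry a six-membered aromatic ring at this place, so it remains open whether a piperidine amine, a carboxylic acid or a five-membered thiazole ring would keep the reading in the same range. As far as these compounds go, the 1-phenylpropyl group of compound 1 differs from the 1-(pyrimidin-5-yl)ethyl group of compound 4 in both ring and chain, and the shared core stays the same throughout, so the separate contribution of the longer chain and any response to changes in the core also remain open.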